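The source may report more compounds than this note shows. Statements on the series, on what has been measured and on what is new or still open speak of the compounds shown alone.

Measured in a functional assay on B16 cells (Mus musculus) for antiproliferative activity, with a stated time of 72 h; on this read-out higher numbers stand for weaker inhibition and lower numbers for stronger inhibition:
- Compound 1 `OC[C@H]1O[C@@H](n2cnc3c(NCc4cccc(Br)c4)ncnc32)[C@H](O)[C@@H]1O`: > 166000 nM
- Compound 2 `OC[C@H]1O[C@@H](n2cnc3c(NCc4c(F)ccc(F)c4F)ncnc32)[C@H](O)[C@@H]1O`: > 166000 nM

Compound 2 stands only at a limit of the assay, > 166000 nM, and this is not a true number. Compound 3 `Cc1ccc(O)c(CNc2ncnc3c2ncn3[C@@H]2O[C@H](CO)[C@@H](O)[C@H]2O)c1` has 2-hydroxy-5-methylphenyl in place of 2,3,6-trifluorophenyl on a saturated chain carbon bound to a nitrogen on an aromatic ring. For the measured compounds named here, the one measured step, a step that the two limits leave unreadable from compound 1 to compound 2, has no readable size, and the remaining evidence is the limit of > 166000 nM in this assay, at which 2 of the 2 values shown sit. In this assay, then, little change is expected, perhaps a small gain in inhibition. The expected step is an at least 1.2-fold lower number from compound 2 to compound 3 (0.10 log units; that floor lies within the scatter). For compound 3 the estimate is 130000 nM, with an expected range of 30000 nM to 350000 nM.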

Compound 3, half-maximal inhibitory concentration: > 166000 nM
Compound 3: only a limit was reported (the forecaster's own chance of this, stated with the estimate: 65%); middle value at least 1.2-fold (0.10 log units) away from the limit.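

Compound 1, compound 2 and compound 3 all stand only at a limit, not a true number, so no step among them can be read: the limit of > 166000 nM in this assay, at which 3 of the 3 values shown sit.

From the compounds shown here alone, what stays open is how strongly each compound inhibits, and whether swapping these aromatic groups changes that at all.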